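Benzyl Carbamate Analogue: Cytotoxicity Held at the Assay Ceiling

The source may report more compounds than this note shows. Statements on the series, on what has been measured and on what is new or still open speak of the compounds shown alone.

Compound 1 `CCCCNC(=O)Nc1cc2nc(C3CCCCC3)[nH]c2cc1N(CC)CC` gives > 100 ug/mL in an ADME assay on Vero cells (Chlorocebus sabaeus) for cytotoxicity, read by resazurin assay, with a stated time of 3 days (on this read-out higher numbers stand for weaker inhibition and lower numbers for stronger inhibition), a limit rather than a number.
Compound 2 `CCCCOC(=O)Nc1cc2nc(C3CCCCC3)[nH]c2cc1N(C)C` gives > 100 ug/mL in this assay, again a limit.
Compound 3 `CCCCOC(=O)Nc1cc2nc(C3CCCCC3)[nH]c2cc1N(CCC)CCC` gives > 100 ug/mL in this assay, also a limit.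

Compound 3 therefore stands at the ceiling of the measured range, together with the two other compounds shown, since all three sit at the limit of > 100 ug/mL in this assay, at which 3 of the 3 values shown sit. For the measured compounds named here, the only step between measured compounds, a step that the two limits leave unreadable from compound 2 to compound 3, is unreadable because both ends are limits. Compound 4 `CCCN(CCC)c1cc2[nH]c(C3CCCCC3)nc2cc1NC(=O)OCc1ccccc1` differs from compound 3 by phenyl in place of propyl on a saturated chain carbon bound to an oxygen next to a carbonyl group. Going by the values given here, no measured step touches this part of the molecule, so there is nothing in the data to suggest a readable change. Compound 4 is expected to remain at the ceiling, with a step from compound 3 of a step that the limit leaves unreadable from compound 3 to compound 4. Compound 4 is estimated at 150 ug/mL, within 50 ug/mL to 500 ug/mL.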

Compound 4, half-maximal inhibitory concentration: > 100 ug/mL
Compound 4 ended at the assay's limit; the forecaster's own chance of this, stated with the estimate: 80%; the middle value is on the limit's open side.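

In this assay, for the compounds shown here, compound 4 gives > 100 ug/mL and this is a limit, so no step from compound 3 to compound 4 can be read. The compounds shown leave open at what concentration any of them would become cytotoxic.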